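This account rests on a few compounds, and the source may have more. Where it says the series, first, only, none or still open, it means among the compounds named here.

Compound 3 `O=C1[C@H](Cc2n[nH]c3ccccc23)C(=O)N(c2ccccc2)C=CN1CC(=O)N1CCCCc2ccccc21` gives 61.7 nM in a functional assay on CHO cells for agonist activity at Melanocyte-stimulating hormone receptor (Homo sapiens), read by a luciferase reporter, with a stated time of 4 h; on this read-out higher numbers stand for an effect only at larger amounts of compound and lower numbers for an effect already at smaller amounts. Compound 1 `COc1ccc(N(C(=O)CN2C=CN(c3ccccc3)C(=O)[C@@H](Cc3n[nH]c4ccccc34)C2=O)C(C)C)cc1` carries a group of 12 heavy atoms (10 carbon, 1 nitrogen, 1 oxygen; one six-membered aromatic ring of carbon only) in place of a group of 11 heavy atoms (10 carbon, 1 nitrogen; one six-membered aromatic ring of carbon only, one seven-membered non-aromatic ring with 1 hetero atom), on a carbonyl carbon and in this assay compound 1 gives 1550 nM, so the step of a 25-fold higher number from compound 3 to compound 1 (1.40 log units; beyond the scatter). Compound 2 `O=C1C(Cc2n[nH]c3cc(F)ccc23)C(=O)N(c2ccccc2)C=CN1CC(=O)N1CCCCc2ccccc21` gives 1.59 nM in this assay; how its core differs from that of compound 3 is not broken down here, and the two values stand far apart. Compound 4 `COc1ccc(N(C(=O)CN2C=CN(c3ccccc3)C(=O)C(Cc3n[nH]c4cc(F)ccc34)C2=O)C(C)C)cc1` has not been measured; it carries a group of 12 heavy atoms (10 carbon, 1 nitrogen, 1 oxygen; one six-membered aromatic ring of carbon only) in place of a group of 11 heavy atoms (10 carbon, 1 nitrogen; one six-membered aromatic ring of carbon only, one seven-membered non-aromatic ring with 1 hetero atom), on a carbonyl carbon, the same kind of change as from compound 3 to compound 1, with the place described in the same words. Expected on this basis is a step of similar size, a 25-fold higher number from compound 2 to compound 4 (1.40 log units; beyond the scatter), because the only measured instance of this change is a 25-fold higher number from compound 3 to compound 1 (1.40 log units; beyond the scatter). Compound 4 is therefore estimated at 40 nM in this assay, between 10 nM and 160 nM.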

Compound 4, half-maximal effective concentration: 1.59 nM
Estimate against measurement, compound 4: 25-fold (1.40 log units) above, outside the stated range (below it).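

In this assay, exchanging the group with the seven-membered non-aromatic ring for isopropyl(4-methoxyphenyl)amino on a carbonyl carbon gives no change at the digits printed from compound 2 to compound 4 (within the scatter). This change therefore does not carry over as a fixed step between these two cores: the same change on two cores in this assay, a 25-fold higher number (1.40 log units; beyond the scatter) from compound 3 to compound 1 and no change at the digits printed (within the scatter) from compound 2 to compound 4, 25-fold (1.40 log units) apart, beyond the scatter of two such steps

The two pairs show that the outcome of this change depends on the core, but they do not show which feature of the cores is responsible or give a rule for any other core.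

From the compounds shown here alone, it remains open how other groups on this carbonyl carbon, such as a simple amine or a longer alkyl chain, would behave on each core. Going by these compounds, it also remains open whether either pair's result is typical of the series.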